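From a Methyl Thioether to a Chlorobenzyl Thioether

The source may hold more compounds than are shown below. What is called first, only, known or untested is meant among the compounds shown, and "the series" means these compounds.

Compound 3 `CSc1nnc(C)n1N1C(=O)c2ccccc2C1=O` is the smallest member of the set, carrying only a methyl on the sulfur. In a functional assay on PC-3M cells (Homo sapiens) for cytotoxicity, read by MTT assay, with a stated time of 48 h (on this read-out lower numbers stand for stronger inhibition and higher numbers for weaker inhibition), compound 3 reaches just a limit, > 200000 nM. Its companions are compound 1 `Cc1nnc(SCc2ccccc2)n1N1C(=O)c2ccccc2C1=O`, with a benzyl on the sulfur, and compound 2 `CCOC(=O)CSc1nnc(C)n1N1C(=O)c2ccccc2C1=O`, with an ethoxycarbonylmethyl there. In this assay compound 1 likewise stops at a limit, > 200000 nM. Compound 2 also gives only a limit in this assay, > 200000 nM. Because every value rests on (the limit of > 200000 nM in this assay, at which 3 of the 3 values shown sit), the steps a step that the two limits leave unreadable from compound 1 to compound 2, a step that the two limits leave unreadable from compound 1 to compound 3 and a step that the two limits leave unreadable from compound 2 to compound 3 carry no readable size.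

Compound 4 `Cc1nnc(SCc2ccccc2Cl)n1N1C(=O)c2ccccc2C1=O` differs from compound 3 by 2-chlorophenyl in place of hydrogen on a saturated chain carbon bound to a sulfur. The nearest comparison is compound 1, whose unsubstituted benzyl did not bring the value under the limit, so no shift beyond the scatter is expected for the step of a number no higher from compound 3 to compound 4 (the limit leaves the size open). Compound 4 is therefore estimated at 200000 nM, between 60000 nM and 600000 nM, and most probably it will again be reported only as a limit.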

Compound 4, half-maximal inhibitory concentration: > 200000 nM
Compound 4 ended at the assay's limit; the forecaster's own chance of this, stated with the estimate: 80%; the middle value sits exactly at the limit.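

No new step can be read for compound 4 against compound 1, compound 2 or compound 3, because all four compounds rest on one limit: the limit of > 200000 nM in this assay, at which 4 of the 4 values shown sit. The compounds shown leave open whether any group on the sulfur can bring a value in this assay under that limit.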